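This account rests on a few compounds, and the source may have more. Where it says the series, first, only, none or still open, it means among the compounds named here.

Measured compounds:
compound 1, `CCC1(Cc2ccccc2)OS(=O)(=O)C=C1OC`: > 400000 nM
compound 2, `CCC1(Cc2ccccc2)OS(=O)(=O)C=C1OCCc1ccccc1`: >= 20000 nM

In an ADME assay on HEL cells (Homo sapiens) for cytotoxicity, with a stated time of 3 days (a higher number here means that more compound is tolerated, a lower number that less compound is tolerated), compound 1 reaches only a limit of the assay, > 400000 nM. Compound 2 likewise gives only a limit in this assay, >= 20000 nM. Compound 2 therefore stands at one of the two limits shown, with no number of its own, and the single step recorded to it, a step that the two limits leave unreadable from compound 1 to compound 2, cannot be read in size. Compound 3, `CCC1(Cc2ccccc2)OS(=O)(=O)C=C1OCc1ccccc1`, is the unmeasured member; its change from compound 2 is phenyl in place of benzyl on a saturated chain carbon bound to an oxygen on an unsaturated carbon. Within the data shown here, only the step ending at compound 2 bears on this change, and that step is unreadable, so no direction beyond the scatter is expected in this assay for compound 3. The expected step is a step that the limit leaves unreadable from compound 2 to compound 3. Compound 3 is estimated at 50000 nM, between 15000 nM and 400000 nM, most probably again reported as a limit.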

Compound 3, minimum cytotoxic concentration: >= 50000 nM
Compound 3 ended at the assay's limit; the forecaster's own chance of this, stated with the estimate: 70%; the middle value sits exactly at the limit.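

Among these compounds, compound 3 also gives only a limit, >= 50000 nM, so no step among compound 1, compound 2 and compound 3 can be read in this assay. Left open is whether hydrogen, phenyl or benzyl on a saturated chain carbon bound to an oxygen on an unsaturated carbon changes the minimum cytotoxic concentration at all.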